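Swapping the Ring on the Carbonyl of Compound 3

The source may hold more compounds than are shown below. What is called first, only, known or untested is meant among the compounds shown, and "the series" means these compounds.

Three measured compounds share one core and differ only in the ring attached to a carbonyl carbon. In a functional assay on CHO cells for activation of adenosine receptor A2b (Homo sapiens), read by cAMP accumulation (on this read-out lower numbers stand for an effect already at smaller amounts and higher numbers for an effect only at larger amounts of compound), compound 3 `CCNC(=O)[C@H]1O[C@@H](n2cnc3c(NNC(=O)c4ccc[nH]4)nc(Cl)nc32)[C@H](O)[C@@H]1O` gives 359 nM, the highest of the two numbers available; compound 2 `CCNC(=O)[C@H]1O[C@@H](n2cnc3c(NNC(=O)c4ccco4)nc(Cl)nc32)[C@H](O)[C@@H]1O` gives 210 nM, and a 1.7-fold higher number from compound 2 to compound 3 (0.23 log units; within the scatter). Compound 1 `CCNC(=O)[C@H]1O[C@@H](n2cnc3c(NNC(=O)c4ccccc4)nc(Cl)nc32)[C@H](O)[C@@H]1O` reaches only a limit of the assay, > 5000 nM. The steps of an at least 23-fold lower number from compound 1 to compound 2 (1.37 log units; beyond the scatter) and an at least 13-fold lower number from compound 1 to compound 3 (1.14 log units; beyond the scatter) show that a five-membered ring with one hetero atom fares far better than a plain phenyl here. Compound 4 `CCNC(=O)[C@H]1O[C@@H](n2cnc3c(NNC(=O)c4cc(-c5ccccc5)on4)nc(Cl)nc32)[C@H](O)[C@@H]1O` carries the change (5-phenyl-1,2-oxazol-3-yl in place of 1H-pyrrol-2-yl on a carbonyl carbon). The entering group again brings a phenyl, which in compound 1 gave only a limit (the limit of > 5000 nM in this assay, at which 1 of the 3 values shown sits), though now attached to a five-membered ring with two hetero atoms. A weaker effect is therefore expected for compound 4, with a 4.2-fold higher number from compound 3 to compound 4 (0.62 log units; beyond the scatter). The estimate for compound 4 is 1500 nM, in the range 300 nM to 8000 nM.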

Compound 4, half-maximal effective concentration: > 5000 nM
Compound 4 gave a limit, no number; the forecaster's own chance of this, stated with the estimate: 30%; at least 3.3-fold (0.52 log units) between middle value and limit.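

In this assay, a five-membered aromatic ring on the carbonyl carbon does not by itself preserve the effect: 5-phenyl-1,2-oxazol-3-yl gives an at least 13-fold higher number from compound 3 to compound 4 (1.14 log units; beyond the scatter) and an at least 23-fold higher number from compound 2 to compound 4 (1.37 log units; beyond the scatter). The step between compound 1 and compound 4 cannot be read, and compound 4 gives a limit of the assay, not a number: the limit of > 5000 nM in this assay, at which 2 of the 4 values shown sit.

From the compounds shown here alone, it remains open whether the phenyl or the 1,2-oxazol-3-yl ring accounts for this loss. A plain 1,2-oxazol-3-yl or a 5-methyl-1,2-oxazol-3-yl on the carbonyl carbon would separate the two.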